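Swapping the sulfonium of compound 2 for a diamine

This account rests on a few compounds, and the source may have more. Where it says the series, first, only, none or still open, it means among the compounds named here.

Measured compounds:
compound 1 `C[S+](CCC(C)(N)C(=O)O)C[C@H]1O[C@@H](n2cnc3c(N)ncnc32)[C@H](O)[C@@H]1O` with 180000 nM in an assay for inhibition of S-adenosylmethionine decarboxylase proenzyme (Rattus norvegicus); on this read-out lower numbers stand for stronger inhibition and higher numbers for weaker inhibition
compound 2 `CC(N)CC[S+](C)C[C@H]1O[C@@H](n2cnc3c(N)ncnc32)[C@H](O)[C@@H]1O` with 120000 nM in this assay

Compound 2 has the lowest of the two numbers, yet the measured step between them is a 1.5-fold lower number from compound 1 to compound 2 (0.18 log units; within the scatter), so the two stand together. Compound 3 `CN(CCCN)C[C@H]1O[C@@H](n2cnc3c(N)ncnc32)[C@H](O)[C@@H]1O` differs from compound 2 by a group of 6 heavy atoms (4 carbon, 2 nitrogen; no ring) in place of a group of 7 heavy atoms (5 carbon, 1 nitrogen, 1 sulfur; no ring), on a saturated chain carbon bound to a saturated ring carbon. Among the compounds with values here, no measured step touches this change; the one recorded step concerns only a carboxy. Compound 3 is therefore expected near compound 2, with an estimated step of a 2.1-fold higher number from compound 2 to compound 3 (0.32 log units; beyond the scatter) in this assay. The estimate for compound 3 is 250000 nM, within 50000 nM to 1500000 nM.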

Compound 3, inhibition constant: 110000 nM
Compound 3: middle estimate off by 2.3-fold (0.36 log units), on the high side, within the range that was stated.
By their numbers in this assay, from the lowest: compounds 3, 2 and 1 (each within the scatter of the next).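

In this assay, the exchange on a saturated chain carbon bound to a saturated ring carbon gives a 1.1-fold lower number from compound 2 to compound 3 (0.04 log units; within the scatter) and so sets (3-aminopropyl)(methyl)amino, with no net charge, level with the sulfur-bearing group of net charge +1. The earlier step concerned only a carboxy; this one shows that the group at this place can be exchanged with no step beyond the scatter. Nothing available explains this result. Still open, from the compounds shown here alone, is whether a longer chain or a carboxylic acid on the (3-aminopropyl)(methyl)amino group would move the number beyond the scatter.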